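A few compounds are considered here, and "the series" means these few. Any claim that something is new, unique, unknown or untested is made for them only; others in the source may bear on it.

Among the compounds with values here, in a functional assay on MCF7 cells (Homo sapiens) for cytotoxicity, read by MTT assay, with a stated time of 72 h (on this read-out higher numbers stand for weaker inhibition and lower numbers for stronger inhibition), three compounds with a shared core have numbers so far. Compound 1 `O=C1c2c[n+]([O-])c3ccccc3c2C(=O)c2c1c1ccccc1n2Cc1cn(CC(O)CO)nn1` gives 1110 nM, compound 2 `CN1CCN(CCCCn2c3c(c4ccccc42)C(=O)c2c[n+]([O-])c4ccccc4c2C3=O)CC1` gives 100 nM and compound 3 `O=C1c2c[n+]([O-])c3ccccc3c2C(=O)c2c1c1ccccc1n2CCCCN1CCCCC1` gives 150 nM. Compound 3 therefore lies within the scatter of compound 2 and well below compound 1.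

Compound 4 `CN1CCN(CCCCCCn2c3c(c4ccccc42)C(=O)c2c[n+]([O-])c4ccccc4c2C3=O)CC1` is still unmeasured. Its difference from compound 3 is this: 2-(4-methylpiperazin-1-yl)ethyl in place of piperidin-1-yl on a saturated chain carbon, four bonds along the chain from an aromatic nitrogen. Cut one bond further out, the change reads 3-(piperidin-1-yl)propyl to 5-(4-methylpiperazin-1-yl)pentyl.

The closest evidence is a 1.5-fold higher number from compound 2 to compound 3 (0.18 log units; within the scatter), a swap between the same two ring groups at the same place. The larger steps, an 11-fold lower number from compound 1 to compound 2 (1.05 log units; beyond the scatter) and a 7.4-fold lower number from compound 1 to compound 3 (0.87 log units; beyond the scatter), both start from a 1-(2,3-dihydroxypropyl)-1H-1,2,3-triazol-4-yl group that compound 4 does not carry, so they bear on it only weakly. Within the data shown here, no measured pair shows the effect of the longer chain alone, which widens the uncertainty.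

In this assay, the expected change is a 1.3-fold lower number from compound 3 to compound 4 (0.10 log units; within the scatter), which would be no step beyond the scatter. For compound 4 the estimated value is 120 nM, with an expected range of 45 nM to 320 nM.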

Compound 4, half-maximal inhibitory concentration: 400 nM
Estimate against measurement, compound 4: 3.3-fold (0.52 log units) below; measured number outside the range, above it.
By their numbers in this assay, from the lowest: compounds 2 and 3 (each within the scatter of the next); then compound 4; then compound 1.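

In this assay, within the data shown here, the longer chain is the first change at this position to show a cost with the 4-methylpiperazin-1-yl ring kept in place, with 5-(4-methylpiperazin-1-yl)pentyl replacing 3-(4-methylpiperazin-1-yl)propyl giving a 4.0-fold higher number from compound 2 to compound 4 (0.60 log units; beyond the scatter). Among these compounds, the earlier compounds showed only that the two ring groups gave numbers within the scatter of each other on the shorter chain, whereas the comparison with the piperidine compound now gives a 2.7-fold higher number from compound 3 to compound 4 (0.43 log units; beyond the scatter), and the longer chain still keeps an advantage over the triazole group, with a 2.8-fold lower number from compound 1 to compound 4 (0.44 log units; beyond the scatter). No measurement here gives a reason for the loss on the longer chain.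

Still open, going by these compounds, is how 5-(piperidin-1-yl)pentyl would compare, which would show whether the loss follows the chain whichever ring it carries. Also open, on these data alone, is how a shorter 2-(4-methylpiperazin-1-yl)ethyl chain, or a morpholine ring at the chain end, would read.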